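Oxygen-linked variation in the tricyclic series: ester for benzyl ether

The source may report more compounds than this note shows. Statements on the series, on what has been measured and on what is new or still open speak of the compounds shown alone.

The series shares one core. Compound 1 `Cc1nn(-c2ncnc3nc[nH]c23)c2c1C(c1ccc(OC(C)C)cc1)CC(=O)N2`, compound 2 `Cc1nn(-c2ncnc3nc[nH]c23)c2c1C(c1ccc(F)cc1Cl)CC(=O)N2` and compound 3 `Cc1nn(-c2ncnc3nc[nH]c23)c2c1C(OCc1ccc(C(C)C)cc1)CC(=O)N2` have been measured in a functional assay on HEK293 cells for agonist activity at G-protein coupled receptor 39 (Homo sapiens), read by scintillation proximity assay and inositol phosphate accumulation, with a stated time of 75 min, in the presence of a further agent that is not named here; on this read-out higher numbers stand for an effect only at larger amounts of compound and lower numbers for an effect already at smaller amounts. Compound 1 gives 18 nM, compound 2 gives 9 nM and compound 3 gives 5 nM. Going by the values given here, the only one-place step among them is a 2.0-fold lower number from compound 1 to compound 2 (0.30 log units; within the scatter), which shows that exchanging the aryl group on the saturated ring carbon leaves the number within the scatter. Compound 3 has the lowest number of the three: against compound 2 the two values sit within the scatter, so no order between them is claimed; against compound 1 the gap lies beyond the scatter.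

Compound 4 `Cc1nn(-c2ncnc3nc[nH]c23)c2c1C(OC(=O)c1ccc(F)cc1)CC(=O)N2` differs from compound 3 in one place: (4-fluorophenyl)carbonyl in place of 4-isopropylbenzyl on an oxygen on a saturated carbon. No measured step varies the group on this oxygen, so nothing shown bears directly on it; the step from compound 1 to compound 2 only indicates that aryl exchange elsewhere in the series was tolerated. The estimate therefore stays close to compound 3, with a broad range, and the expected step is a 2.0-fold higher number from compound 3 to compound 4 (0.30 log units; within the scatter), not beyond the scatter. Compound 4 is estimated at 10 nM, between 3 nM and 35 nM.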

Compound 4, half-maximal effective concentration: 4 nM
Beside the measured number, compound 4's estimate is 2.5-fold (0.40 log units) above it, within the range that was stated.
By their numbers in this assay, from the lowest: compounds 4, 3, 2 and 1 (each within the scatter of the next, the first and the last beyond it).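

In this assay the group on an oxygen on a saturated carbon can be exchanged without the number leaving the scatter (a 1.3-fold lower number from compound 3 to compound 4 (0.10 log units; within the scatter)), so the 4-isopropylbenzyl and (4-fluorophenyl)carbonyl groups are not told apart here, even though only the latter brings a double bond outside aromatic rings and a hydrogen-bond acceptor. The series also now has steps beyond the scatter, both modest, at the saturated ring carbon: ((4-fluorophenyl)carbonyl)oxy in place of 2-chloro-4-fluorophenyl (a 2.3-fold lower number from compound 2 to compound 4 (0.35 log units; beyond the scatter)) and in place of 4-isopropoxyphenyl (a 4.5-fold lower number from compound 1 to compound 4 (0.65 log units; beyond the scatter)). Nothing at hand explains any of these steps.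

Compound 3 and compound 4 differ in both the carbonyl and the fluorine, so the shown compounds cannot assign the result to either feature, nor to the loss of the isopropyl group. Going by these compounds, how an amide in place of the ester, a longer chain on the oxygen, or an amine or carboxylic acid on the phenyl ring would read remains open.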